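The compounds below may be only part of what the source reports. "The series", "measured", "known", "first", "only" and "open" are said of these compounds alone.

Measured compounds, all read in a functional assay on UO-31 cells (Homo sapiens) for inhibition, read by sulforhodamine B assay, with a stated time of 48 h; a higher number here means a weaker inhibitor of growth, a lower number a stronger inhibitor of growth:

- compound 1, `COc1cc(CNc2nc3cc(N)cc(N)c3nc2-c2ccccc2)cc(OC)c1OC`, gives 11200 nM
- compound 2, `CCOC(=O)[C@H](CCC(=O)O)NC(=O)c1ccc(Oc2nc3cc(N)cc(N)c3nc2-c2ccccc2)cc1`, gives 11200 nM
- compound 3, `COc1ccc(CNc2nc3cc(N)cc(N)c3nc2-c2ccccc2)cc1OC`, gives 13500 nM

Compound 3 holds the highest of the three numbers in this assay, yet its distance to compound 1 and to compound 2 is within the scatter, so the three compounds are not separated from one another on these data.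

The next compound is compound 4, `COc1ccc(CNc2nc3cc(N)cc(N)c3nc2-c2ccccc2)cc1`, not yet measured. It differs from compound 3 in one place: hydrogen in place of methoxy on an aromatic carbon. Cut one bond further out, the same difference reads 3,4-dimethoxyphenyl to 4-methoxyphenyl.

Within the data shown here, one measured step bears on this: a 1.2-fold higher number from compound 1 to compound 3 (0.08 log units; within the scatter), which removes a methoxy group from the same aromatic ring of the shared core. That step fell within the scatter. On that single precedent, removing a further methoxy group is expected to give no step beyond the scatter in this assay, in either direction, so compound 4 is expected to sit near compound 3, at a step of a 1.0-fold higher number from compound 3 to compound 4 (0.02 log units; within the scatter).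

Compound 4 is therefore estimated at 14000 nM, with a range of 7000 nM to 28000 nM.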

Compound 4, concentration for 50% growth inhibition: 11500 nM
For compound 4 the middle estimate is 1.2-fold (0.09 log units) above the measured one; low and high end bracket the measured number.
By their numbers in this assay, from the lowest: compounds 1, 2, 4 and 3 (each within the scatter of the next).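

With the 3,4-dimethoxyphenyl to 4-methoxyphenyl change, this assay gives a 1.2-fold lower number from compound 3 to compound 4 (0.07 log units; within the scatter), so a methoxy group ortho to a methoxy group can give way to hydrogen with no step beyond the scatter. Together with a 1.2-fold higher number from compound 1 to compound 3 (0.08 log units; within the scatter), this makes two single methoxy-to-hydrogen changes on this aromatic ring that leave the compounds unseparated. No measurement shown here offers an explanation for this flat result.

Still open, as far as these compounds go, is whether an amine, a carboxylic acid or a longer chain at this place would give a step beyond the scatter in this assay and in which direction. Also open, from the compounds shown here alone, is what replacing the remaining methoxy group of compound 4 with hydrogen would do.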